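This account rests on a few compounds, and the source may have more. Where it says the series, first, only, none or still open, it means among the compounds named here.

The measured compounds in a functional assay on C6 cells (Rattus norvegicus) for cytotoxicity, read by MTT assay, with a stated time of 24 h, tested at 12 ug/mL; on this read-out higher numbers stand for a weaker effect at the one concentration tested and lower numbers for a stronger effect:
Compound 1 `Cc1ccc(-c2cs/c(=N/NC(=O)CSc3nnnn3-c3ccccc3)n2-c2ccccc2)cc1` gives 55.1%.
Compound 2 `Cn1nnnc1SCC(=O)N/N=c1/scc(-c2ccccc2)n1-c1ccccc1` gives 80.7%.
Compound 3 `O=C(CSc1nnnn1-c1ccccc1)N/N=c1/scc(-c2ccccc2)n1-c1ccccc1` gives 47.1%.

Compound 2 stands highest of the three, with compound 1 nearest and compound 3 furthest, both gaps beyond the scatter. Compound 4 `Cn1nnnc1SCC(=O)N/N=c1/scc(-c2ccc([N+](=O)[O-])cc2)n1-c1ccccc1` differs from compound 2 by nitro in place of hydrogen on an aromatic carbon. Among the compounds with values here, no measured step makes this change. The closest comparison is the step from compound 1 to compound 3, a number 8 percentage points lower from compound 1 to compound 3 (within the scatter), where a group on an aromatic carbon was exchanged. The step of a number 33.6 percentage points lower from compound 2 to compound 3 (beyond the scatter) concerns the aromatic nitrogen and does not bear on the present change. A step of about a number 5.7 percentage points lower from compound 2 to compound 4 (within the scatter) is therefore expected, none beyond the scatter. Compound 4 is estimated at 75%, within 55% to 95%.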

Compound 4, a percentage reported as activity, at one concentration (the size of the read-out at that concentration, not a potency): 76.2%
For compound 4 the middle estimate is 1.2 percentage points below the measured one, and the stated range covers the measured number.
By their numbers in this assay, from the lowest: compounds 3 and 1 (each within the scatter of the next); then compounds 4 and 2 (each within the scatter of the next).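

In this assay, the change from phenyl to 4-nitrophenyl, on an aromatic carbon para to a large group, gives a number 4.5 percentage points lower from compound 2 to compound 4 (within the scatter). Until now this position had been read only with phenyl on the aromatic nitrogen, as a number 8 percentage points lower from compound 1 to compound 3 (within the scatter), so this is its first reading with methyl there, and this change also stays within the scatter. Nothing available accounts for the result. On these data alone, whether an amine or a carboxylic acid at this position would move the number beyond the scatter remains open. So does the effect of nitro with phenyl on the aromatic nitrogen.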